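An amino group takes the place of fluoro in compound 3

A few compounds are considered here, and "the series" means these few. Any claim that something is new, unique, unknown or untested is made for them only; others in the source may bear on it.

Measured in a functional assay on MGC-803 cells (Homo sapiens) for inhibition, read by CCK-8 assay, with a stated time of 48 h; on this read-out higher numbers stand for weaker inhibition and lower numbers for stronger inhibition:
- compound 1 `CCN1CCN(C(=S)SCC(=O)N(Cc2ccc(OC)cc2)c2cc(OC)c(OC)c(OC)c2)CC1`: 9890 nM
- compound 2 `COc1cc(N(Cc2ccc(Br)cc2)C(=O)CSC(=S)N2CCN(C(=O)OC(C)(C)C)CC2)cc(OC)c1OC`: 12400 nM
- compound 3 `COc1ccc(CN(C(=O)CSC(=S)N2CCN(C(=O)OC(C)(C)C)CC2)c2cc(OC)c(OC)c(OC)c2)cc1F`: 4870 nM

Of these three, compound 3 has the lowest number, 4870 nM, and so the strongest inhibition in this assay. Both other values are higher, beyond the usual scatter.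

Compound 4 `COc1ccc(CN(C(=O)CSC(=S)N2CCN(C(=O)OC(C)(C)C)CC2)c2cc(OC)c(OC)c(OC)c2)cc1N` differs from compound 3 in one substituent: amino in place of fluoro on an aromatic carbon, ortho to a methoxy group, which turns 3-fluoro-4-methoxybenzyl into 3-amino-4-methoxybenzyl (amino in place of fluoro on an aromatic carbon).

Among the compounds with values here, only one measured step touches this part of the molecule: a 2.5-fold lower number from compound 2 to compound 3 (0.41 log units; beyond the scatter). It shows that a change on this aromatic ring can move the number, though modestly. Within the data shown here, it says nothing about amino itself, and no measured pair compares fluoro with amino. Compound 1 differs from compound 3 in more than one place and offers no clean guide.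

A step no larger than that modest one is therefore expected, most likely none beyond the scatter, with no firm direction. The expected step is a 1.2-fold lower number from compound 3 to compound 4 (0.09 log units; within the scatter). The estimated value for compound 4 is 4000 nM, with an expected range of 1300 nM to 11000 nM.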

Compound 4, half-maximal inhibitory concentration: 184 nM
Beside the measured number, compound 4's estimate is 22-fold (1.34 log units) above it, and the stated range ends above it.
By their numbers in this assay, from the lowest: compound 4; then compound 3; then compounds 1 and 2 (each within the scatter of the next).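

In this assay, within the data shown here, the aromatic carbon ortho to a methoxy group proves far more sensitive than the earlier compounds suggested: amino in place of fluoro gives a 26-fold lower number from compound 3 to compound 4 (1.42 log units; beyond the scatter) and so exceeds the modest earlier step on this ring, a 2.5-fold lower number from compound 2 to compound 3 (0.41 log units; beyond the scatter), by a wide margin. Taken across the whole group, the change from 4-bromophenyl to 3-amino-4-methoxyphenyl gives a 67-fold lower number from compound 2 to compound 4 (1.83 log units; beyond the scatter) and most of that span lies in the exchange of fluoro for amino, a swap of one heavy atom for one heavy atom that adds one hydrogen-bond donor and one hydrogen-bond acceptor by count. No measurement at hand explains why this exchange has so large an effect.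

The compounds shown leave open whether the step is particular to amino or would also appear with a hydroxy, methylamino, dimethylamino or acetamido group at this carbon. They also leave open whether amino would give a step of similar size on the scaffold of compound 1, which differs from compound 4 at the far end of the molecule as well as on this ring.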